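Swapping the Triazole Substituent on an Inactive Series

The compounds below may be only part of what the source reports. "The series", "measured", "known", "first", "only" and "open" are said of these compounds alone.

Measured compounds:
compound 1, `CCOC(=O)C1=Cc2ccccc2OC1(OCc1cn(CC(=O)Nc2cccc(F)c2)nn1)C(F)(F)F`: > 150000 nM
compound 2, `O=C(O)C1=Cc2ccccc2OC1(OCc1cc(-c2ccc(F)cc2F)no1)C(F)(F)F`: > 150000 nM
compound 3, `O=C(O)C1=Cc2ccccc2OC1(OCc1cc(-c2ccc3ccccc3c2)no1)C(F)(F)F`: > 150000 nM

In a functional assay on HeLa cells (Homo sapiens) for inhibition, read by MTT assay, with a stated time of 24 h (on this read-out lower numbers stand for stronger inhibition and higher numbers for weaker inhibition), compound 1 shows no number, only a limit of the assay. The same holds for compound 2, which also sits at the limit. Compound 3 likewise gives only a limit. Among the measured compounds shown here, the one change between measured compounds, naphthalen-2-yl in place of 2,4-difluorophenyl on an aromatic carbon, is therefore a step that the two limits leave unreadable from compound 2 to compound 3. For the measured compounds named here, all three results rest on (the limit of > 150000 nM in this assay, at which 3 of the 3 values shown sit), so no measured step carries readable size.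

Compound 4, `CCOC(=O)C1=Cc2ccccc2OC1(OCc1cn(-c2cccc(OC)c2)nn1)C(F)(F)F`, is not yet measured. It differs from compound 1 by 3-methoxyphenyl in place of ((3-fluorophenyl)carbamoyl)methyl on an aromatic nitrogen. Going by the values given here, no measured step touches this group or this aromatic nitrogen, so nothing among the known compounds says how large a step to expect; the only guide is that every measured compound of the shared core sits at the limit. Compound 4 is therefore expected to stay near that limit as well, with a number no higher from compound 1 to compound 4 (the limit leaves the size open) expected to be none beyond the scatter. The estimate for compound 4 is 150000 nM, with a range from 40000 nM to 400000 nM, and most likely the assay again reports only a limit.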

Compound 4, half-maximal inhibitory concentration: > 150000 nM
Compound 4: only a limit was reported; the forecaster's own chance of this, stated with the estimate: 85%; the middle value lies on the limit itself.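

Compound 4 gives > 150000 nM, a limit and not a number, so no step from compound 1 to compound 4 can be read: the limit of > 150000 nM in this assay, at which 4 of the 4 values shown sit.

The compounds shown leave open whether any compound of the shared core gives a readable number in this assay, and so how much the group on the aromatic nitrogen matters there.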